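The source may hold more compounds than are shown below. What is called first, only, known or untested is meant among the compounds shown, and "the series" means these compounds.

Values in a functional assay (Homo sapiens) (on this read-out higher numbers stand for weaker inhibition and lower numbers for stronger inhibition), so far:
- compound 1 `C#Cc1cccc(-c2nccc3nc(N)nn23)c1`: 12600 nM; 12600 nM (2 entries) (two entries with the same value)
- compound 2 `Nc1nc2ccnc(-c3cccc(C(Cl)Cl)c3)n2n1`: 1000 nM
- compound 3 `Cc1ccc(S(=O)(=O)Nc2cccc(-c3nccc4nc(N)nn34)c2)cc1`: 1500 nM

Compound 2 and compound 3 sit within the scatter of each other, and together they hold the low end of the three numbers. Compound 1 stands well apart at a higher number.

The next compound is compound 4 `CCOC(=O)c1cccc(-c2nccc3nc(N)nn23)c1`, which has ethoxycarbonyl in place of dichloromethyl on an aromatic carbon. For the measured compounds named here, no measured pair in this set differs in one place only, so no step can be carried over. The expectation rests only on the spread of the values, where compound 3 (1500 nM) lies close to compound 2 and compound 1 (12600 nM; 12600 nM (2 entries)) lies far higher. A moderate move towards a higher number in this assay is expected, though one within the scatter cannot be ruled out. The estimated change is a 3.0-fold higher number from compound 2 to compound 4 (0.48 log units; beyond the scatter) as a working figure. For compound 4 the expected value is 3000 nM (estimated range 800 nM to 12000 nM).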

Compound 4, half-maximal inhibitory concentration: 11500 nM
The estimate for compound 4 lay 3.8-fold (0.58 log units) below the measured number; low and high end bracket the measured number.
By their numbers in this assay, from the lowest: compounds 2 and 3 (each within the scatter of the next); then compound 4.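

In this assay, ethoxycarbonyl in place of dichloromethyl on an aromatic carbon gives a 12-fold higher number from compound 2 to compound 4 (1.06 log units; beyond the scatter), so this position, meta to a large group, is shown for the first time to respond strongly to a change of this one group. The step cannot be split into its parts, since the entering group brings more heavy atoms, a double bond and hydrogen-bond acceptors all at once, while dichloromethyl has no hydrogen-bond acceptors. No measurement at hand bears on the reason for the size of this step.

On these data alone, whether the higher number follows the carbonyl or the ethyl part of the ester stays open, and a carboxylic acid, a methyl ester or a primary amide on the same aromatic carbon would separate the two. As far as these compounds go, it is also open how much of the low number of compound 2 depends on its two chlorines, which a chloromethyl or a plain methyl group in that place would test.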